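This account rests on a few compounds, and the source may have more. Where it says the series, first, only, none or still open, it means among the compounds named here.

Compound 3, `COc1ccc(OC)c2c1C(=O)C=C(C(C)O)C2=O`, is the reference point of this account. In a functional assay on L1210 cells (Mus musculus) for cytotoxicity (on this read-out higher numbers stand for an effect only at larger amounts of compound and lower numbers for an effect already at smaller amounts), compound 3 gives 0.487 ug/mL, the highest of the three numbers recorded so far, yet its steps to both other compounds stay within the scatter. Compound 1, `CCCC(O)C1=CC(=O)c2c(OC)ccc(OC)c2C1=O`, gives 0.409 ug/mL in this assay, and compound 2, `CCCCC(O)C1=CC(=O)c2c(OC)ccc(OC)c2C1=O`, gives 0.412 ug/mL.

Compound 4, `CCCCCCC(O)C1=CC(=O)c2c(OC)ccc(OC)c2C1=O`, differs from compound 3 by pentyl in place of hydrogen on a saturated chain carbon, two bonds along the chain from a double-bonded ring carbon and an oxygen on a saturated carbon. The measured steps that bear on this change are the ones reaching compound 3 from the other two: a 1.2-fold higher number from compound 1 to compound 3 (0.08 log units; within the scatter) and a 1.2-fold higher number from compound 2 to compound 3 (0.07 log units; within the scatter), both removing a chain at the same saturated carbon and both within the scatter. The step of a 1.0-fold higher number from compound 1 to compound 2 (0.00 log units; within the scatter), which lengthens the chain by one carbon at a more distant position, is likewise within the scatter. Taken together, these steps show no response of this assay to the length of the chain on that carbon, and the step from compound 3 to compound 4 is therefore expected to be none beyond the scatter, a 1.2-fold lower number from compound 3 to compound 4 (0.06 log units; within the scatter). For compound 4 the estimate is 0.42 ug/mL, with a range from 0.2 ug/mL to 0.9 ug/mL, pending the actual measurement.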

Compound 4, concentration for half-maximal effect: 0.732 ug/mL
The estimate for compound 4 lay 1.7-fold (0.24 log units) below the measured number; the measured number falls inside the stated range.
By their numbers in this assay, from the lowest: compounds 1, 2, 3 and 4 (each within the scatter of the next).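

In this assay, the pentyl group on this saturated chain carbon gives a 1.5-fold higher number from compound 3 to compound 4 (0.18 log units; within the scatter), and the two comparisons with the intermediate chains give a 1.8-fold higher number from compound 2 to compound 4 (0.25 log units; within the scatter) and a 1.8-fold higher number from compound 1 to compound 4 (0.25 log units; within the scatter). The earlier compounds shown here covered only shorter chains, so compound 4 extends the tolerated range at this position: even the change from 1-hydroxyethyl to 1-hydroxyheptyl does not take the read-out beyond the scatter, though these steps from compound 4 are larger than the earlier steps among compounds 1, 2 and 3. Comparing the same change on two cores likewise separates no effect of the core: the same change on two cores in this assay, a 1.2-fold higher number (0.08 log units; within the scatter) from compound 1 to compound 3 and a 1.8-fold lower number (0.25 log units; within the scatter) from compound 4 to compound 2, 2.1-fold (0.33 log units) apart, within the scatter of two such steps. A second such comparison agrees: the same change on two cores in this assay, a 1.2-fold higher number (0.07 log units; within the scatter) from compound 2 to compound 3 and a 1.8-fold lower number (0.25 log units; within the scatter) from compound 4 to compound 1, 2.1-fold (0.33 log units) apart, within the scatter of two such steps.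

The compounds shown leave open whether a longer chain such as decyl, or an amine or a carboxylic acid in place of pentyl on that saturated chain carbon, would produce a step beyond the scatter in this assay. With every step here within the scatter, they also establish no ordering by chain length.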